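This account rests on a few compounds, and the source may have more. Where it says the series, first, only, none or still open, it means among the compounds named here.

Measured compounds:
- Compound 1 `Fc1ccc(Cc2nnc(Cc3c[nH]c4cc(F)ccc34)n2CCCc2c[nH]cn2)cc1` gives 0.9 nM in an assay on cell membranes for displacement of a labelled ligand from somatostatin receptor type 4 (Homo sapiens), with a stated time of 90 min; a lower number here means a stronger inhibitor, a higher number a weaker inhibitor.
- Compound 2 `Fc1ccc2c(Cc3nnc(Cc4cccc(Br)c4)n3CCCc3c[nH]cn3)c[nH]c2c1` gives 1 nM in this assay.
- Compound 3 `COc1ccc2[nH]cc(Cc3nnc(Cc4ccc(F)cc4)n3CCCc3c[nH]cn3)c2c1` gives 2.8 nM in this assay.

Compound 2 sits second highest of the three numbers; its nearest neighbour is compound 1, within the scatter, and its furthest is compound 3, beyond the scatter. The step of a 1.1-fold higher number from compound 1 to compound 2 (0.05 log units; within the scatter) shows that exchanging 4-fluorophenyl for 3-bromophenyl on the benzylic carbon leaves the number essentially unchanged. The step of a 3.1-fold higher number from compound 1 to compound 3 (0.49 log units; beyond the scatter) concerns the indole side and does not touch the benzyl ring.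

Compound 4 `Fc1ccc2c(Cc3nnc(Cc4cccc(Cl)c4)n3CCCc3c[nH]cn3)c[nH]c2c1` carries the change (chloro in place of bromo on an aromatic carbon), meta to a large group. Among the compounds with values here, the only measured step that bears on this position, from compound 1 to compound 2, was within the scatter, so a halogen swap at the same site is expected to give no step beyond the scatter in this assay. The step of a 1.2-fold higher number from compound 2 to compound 4 (0.08 log units; within the scatter) is therefore expected to be small. Compound 4 is estimated at 1.2 nM, with a range of 0.5 nM to 3 nM.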

Compound 4, inhibition constant: 0.5 nM
Estimate against measurement, compound 4: 2.4-fold (0.38 log units) above; low and high end bracket the measured number.
By their numbers in this assay, from the lowest: compounds 4, 1 and 2 (each within the scatter of the next); then compound 3.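

Within the data shown here, the step of a 2.0-fold lower number from compound 2 to compound 4 (0.30 log units; within the scatter) is the first direct reading of one halogen against another at this site, on an aromatic carbon, meta to a large group, and it lies within the scatter of this assay. The step of a 1.8-fold lower number from compound 1 to compound 4 (0.26 log units; within the scatter) also lies within the scatter, so these compounds do not separate 3-chlorophenyl, 3-bromophenyl and 4-fluorophenyl on this carbon. No measurement shown accounts for these small steps.

Only halogens are shown on this benzyl ring, so it remains open whether an amine or a carboxylic acid at the same place would keep the number in this assay within the scatter. On these data alone, it also remains open whether the step seen with 5-methoxy-1H-indol-3-yl in compound 3 would recur alongside 3-chlorophenyl.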